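Dihydroxyphenyl in place of methoxyphenyl on a shared core

This account rests on a few compounds, and the source may have more. Where it says the series, first, only, none or still open, it means among the compounds named here.

Measured so far in a functional assay on SW-620 cells (Homo sapiens) for cytotoxicity, read by MTT assay, with a stated time of 72 h; a lower number here means a stronger inhibitor, a higher number a weaker inhibitor:
compound 1 `COc1ccc(/C=C2\CCC/C(=C\c3cccc(OC)c3OC)C2=O)cc1OC` gives 6400 nM
compound 2 `COc1cccc(/C=C2\CCC/C(=C\c3ccc(OC)c(OC)c3)C2=O)c1` gives 3700 nM

Compound 2 has the lower of the two numbers in this assay, but the step of a 1.7-fold lower number from compound 1 to compound 2 (0.24 log units; within the scatter) lies within the scatter, so the two measured compounds are not separated by it. Compound 3 `COc1ccc(/C=C2\CCC/C(=C\c3ccc(O)c(O)c3)C2=O)cc1OC` has not yet been measured. It differs from compound 2 in one place: 3,4-dihydroxyphenyl in place of 3-methoxyphenyl on a double-bonded chain carbon bound to a double-bonded ring carbon. Going by the values given here, the only measured step, a 1.7-fold lower number from compound 1 to compound 2 (0.24 log units; within the scatter), concerns a methoxy group on an aromatic carbon and was within the scatter; it does not involve hydroxyl groups, so no measured step bears directly on the change from methoxyphenyl to dihydroxyphenyl. With nothing in the data pointing either way, compound 3 is expected to show a step of a 1.1-fold lower number from compound 2 to compound 3 (0.02 log units; within the scatter) in this assay, with no clear direction beyond the scatter. The number expected for compound 3 is 3500 nM, estimated to fall in a range from 900 nM to 14000 nM, the width reflecting the absence of any measured analogue of this change.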

Compound 3, half-maximal inhibitory concentration: 10500 nM
Estimate against measurement, compound 3: 3.0-fold (0.48 log units) below, and the stated range covers the measured number.
By their numbers in this assay, from the lowest: compounds 2, 1 and 3 (each within the scatter of the next, the first and the last beyond it).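

In this assay, the swap of 3-methoxyphenyl for 3,4-dihydroxyphenyl gives a 2.8-fold higher number from compound 2 to compound 3 (0.45 log units; beyond the scatter), a modest step but the first among these compounds to lie beyond the scatter. The earlier step concerned only a methoxy group on an aromatic carbon and left compound 1 and compound 2 unseparated, whereas this one shows that the number does respond to a change of aryl group at this place, on a double-bonded chain carbon bound to a double-bonded ring carbon, and that here it moves towards weaker inhibition as the group goes from 0 hydrogen-bond donors to 2. Nothing available explains why the number rises with this exchange.

Since the methoxy group leaves and two hydroxyl groups enter in a single step, the compounds shown cannot say whether one hydroxyl group alone would bring the same rise, or whether the loss of the methoxy group already counts for part of it. As far as these compounds go, it also stays open how an amine or a carboxylic acid on this aromatic ring would read in this assay, and whether any group at this place would bring the number down rather than up.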